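This account rests on a few compounds, and the source may have more. Where it says the series, first, only, none or still open, it means among the compounds named here.

Measured in a functional assay on L1210 cells (Mus musculus) for inhibition; a lower number here means a stronger inhibitor, a higher number a weaker inhibitor:
- compound 1 `CCCCCC#C[C@@]1(C)O[C@@H]2OC(=O)N(C(=O)CCl)[C@@H]2CC1=O` gives 31000 nM
- compound 2 `C[C@]1(C#CCCCCc2ccccc2)O[C@@H]2OC(=O)N(C(=O)CCl)[C@@H]2CC1=O` gives 27000 nM

In this assay, among the measured compounds shown here, compound 1 stands level with compound 2, the only other measured compound (a 1.1-fold lower number from compound 1 to compound 2 (0.06 log units; within the scatter)). Compound 3 `CCCCCC1OC1[C@@]1(C)O[C@@H]2OC(=O)N(C(=O)CCl)[C@@H]2CC1=O` is still to be measured. It carries 3-pentyloxiran-2-yl in place of hept-1-yn-1-yl on a saturated ring carbon. For the measured compounds named here, the one measured step changes only the far end of the chain and stays within the scatter (a 1.1-fold lower number from compound 1 to compound 2 (0.06 log units; within the scatter)). Going by the values given here, no measured compound replaces the triple bond, so the data give no direct guide to this change, and that step bears on it only loosely. No shift beyond the scatter is therefore expected in either direction, with wide uncertainty (the expected, estimated step is a 1.1-fold lower number from compound 1 to compound 3 (0.06 log units; within the scatter)). The estimated value for compound 3 is 27000 nM, with an expected range from 10000 nM to 70000 nM.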

Compound 3, half-maximal inhibitory concentration: 193000 nM
Compound 3: middle estimate off by 7.1-fold (0.85 log units), on the low side; the measured number lies above the stated range.
By their numbers in this assay, from the lowest: compounds 2 and 1 (each within the scatter of the next); then compound 3.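

In this assay, putting 3-pentyloxiran-2-yl in place of hept-1-yn-1-yl on the saturated ring carbon next to the ring oxygen gives a 6.2-fold higher number from compound 1 to compound 3 (0.79 log units; beyond the scatter), making compound 3 the weaker inhibitor. Among the compounds shown here, the earlier step changed only the far end of the chain and stayed within the scatter (a 1.1-fold lower number from compound 1 to compound 2 (0.06 log units; within the scatter)), so this is the first sign that inhibition responds to a change at this position. Compound 3 differs from compound 1 both in losing the triple bond and in gaining the three-membered ring, and the pair cannot separate these two changes. No measurement shown here explains the weaker inhibition.

On these data alone, it remains open whether a saturated heptyl chain or a hept-1-en-1-yl group at this position would behave like hept-1-yn-1-yl or like 3-pentyloxiran-2-yl. As far as these compounds go, it also remains open whether a three-membered all-carbon cyclopropane ring would match the oxygen-containing ring.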